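Swapping a halogen for an acetyl group on the shared core

The source may report more compounds than this note shows. Statements on the series, on what has been measured and on what is new or still open speak of the compounds shown alone.

Measured so far in an assay on CHO cells for displacement of a labelled ligand from Substance-P receptor (Homo sapiens); a higher number here means a weaker inhibitor, a lower number a stronger inhibitor:
compound 1, `Cn1c(-c2ccc(Cl)cc2)c(CCC(=O)N2CCC(O)(Cc3ccccc3)CC2)c2cc(Cl)ccc21`, 0.16 nM
compound 2, `Cn1c(-c2ccc(Cl)cc2)c(CCC(=O)N2CCC(O)(Cc3ccccc3)CC2)c2cc(Br)ccc21`, 0.22 nM

Compound 2 holds the highest of the two numbers seen so far, but the step between the two is a 1.4-fold higher number from compound 1 to compound 2 (0.14 log units; within the scatter), so the two compounds cannot be ranked against each other on this evidence. The next compound, compound 3, has the structure `CC(=O)c1ccc2c(c1)c(CCC(=O)N1CCC(O)(Cc3ccccc3)CC1)c(-c1ccc(Cl)cc1)n2C`. Compared with compound 2 the change is acetyl in place of bromo on an aromatic carbon.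

For the measured compounds named here, only one measured step exists, and it compares two halogens at the very same place: a 1.4-fold higher number from compound 1 to compound 2 (0.14 log units; within the scatter). It shows that the core tolerates a change at this carbon without a shift beyond the scatter, but it says nothing about an acetyl group, which brings a hydrogen-bond acceptor where neither halogen had one. The step into compound 3 therefore rests on little direct evidence. The expectation is a small rise in the number, of about a 2.3-fold higher number from compound 2 to compound 3 (0.36 log units; beyond the scatter), with wide uncertainty in both directions. Compound 3 is estimated at 0.5 nM, with a range from 0.1 nM to 3 nM in this assay.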

Compound 3, half-maximal inhibitory concentration: 0.19 nM
Beside the measured number, compound 3's estimate is 2.6-fold (0.42 log units) above it; the measured number falls inside the stated range.
By their numbers in this assay, from the lowest: compounds 1, 3 and 2 (each within the scatter of the next).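

In this assay the change from bromo to acetyl gives a 1.2-fold lower number from compound 2 to compound 3 (0.06 log units; within the scatter) and the change from chloro to acetyl gives a 1.2-fold higher number from compound 1 to compound 3 (0.07 log units; within the scatter) so the acetyl compound cannot be ranked against either halogen compound. Until now this aromatic carbon had been seen carrying only two single-atom halogens, and the new result extends that picture: a group of three heavy atoms, with a double bond outside the aromatic rings and a hydrogen-bond acceptor, also leaves the number within the scatter of both. Nothing available here explains why these three different groups give numbers that cannot be told apart.

The compounds shown leave open how far this holds at the same carbon, for instance whether an amine, a carboxylic acid or a longer chain would also stay within the scatter of these three. On these data alone, they also leave open what a plain hydrogen at this carbon would give, so the contribution of any of these groups to the low numbers seen here remains unknown.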